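Trimming the tail of compound 3: phenyl to methyl

The source may hold more compounds than are shown below. What is called first, only, known or untested is meant among the compounds shown, and "the series" means these compounds.

Of the compounds shown here, three have been tested in an assay on isolated protein for inhibition of deoxycytidine kinase (Rattus norvegicus); on this read-out lower numbers stand for stronger inhibition and higher numbers for weaker inhibition. Compound 1 `CC(C)CCn1ccc(N)nc1=O` gives 5000000 nM. For the measured compounds named here, compound 2 `CCCn1ccc(N)nc1=O` gives 12000000 nM; the only one-place step among the measured set, a 2.4-fold higher number from compound 1 to compound 2 (0.38 log units; beyond the scatter), shows that shortening the saturated chain weakened inhibition by a modest amount. Compound 3 `Nc1ccnc(SCCCCc2ccccc2)n1` gives 1000000 nM, the lowest of the three numbers and therefore the strongest inhibitor here, with compound 1 next and compound 2 furthest away.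

Compound 4 `CCCCCSc1nccc(N)n1` is built from compound 3 by methyl in place of phenyl on a saturated chain carbon, four bonds along the chain from a sulfur. Going by the values given here, no measured step covers this exact change; the nearest comparison is the chain-shortening step between compound 1 and compound 2, where removing carbon from the chain cost potency. Removing the larger phenyl is expected to cost more, so a weakening step is expected, estimated at a 4.0-fold higher number from compound 3 to compound 4 (0.60 log units; beyond the scatter) in this assay. Compound 4 is therefore expected to give about 4000000 nM, within a range of 1000000 nM to 15000000 nM.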

Compound 4, half-maximal inhibitory concentration: 2600000 nM
Estimate against measurement, compound 4: 1.5-fold (0.19 log units) above, and the stated range covers the measured number.
By their numbers in this assay, from the lowest: compound 3; then compounds 4 and 1 (each within the scatter of the next); then compound 2.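

In this assay, for the compounds shown here, methyl in place of phenyl on a saturated chain carbon, four bonds along the chain from a sulfur, gives a 2.6-fold higher number from compound 3 to compound 4 (0.41 log units; beyond the scatter) and is the first look at this end of the chain. Swapping a whole aromatic ring for a single carbon therefore moves the number only modestly, so the phenyl favours inhibition here, but compound 4 keeps a measurable value without it. Nothing available explains why the ring makes this difference.

On these data alone, it remains open whether an aromatic ring is what matters at this place, or whether a cyclohexyl ring or a longer chain would serve as well. As far as these compounds go, how an amine or a carboxylic acid at the end of the chain would compare also remains unknown.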